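Exchanging Trifluoromethyl for Cyano on a Shared Core

This account rests on a few compounds, and the source may have more. Where it says the series, first, only, none or still open, it means among the compounds named here.

Of the compounds shown here, three with one shared core have been tested in an assay on microsomes from liver for inhibition of acyl-CoA desaturase 1 (Rattus norvegicus); on this read-out lower numbers stand for stronger inhibition and higher numbers for weaker inhibition. Compound 1 `Brc1ccccc1OC1CCN(c2ccc(-n3ccnc3)nn2)CC1` gives 5 nM, compound 2 `Cc1ccc(OC2CCN(c3ccc(-n4ccnc4)nn3)CC2)cc1` gives 527 nM, and compound 3 `FC(F)(F)c1ccccc1OC1CCN(c2ccc(-n3ccnc3)nn2)CC1` gives 4 nM, the lowest of the three numbers. Compound 3 and compound 1 lie within the scatter of each other, because a 1.3-fold lower number from compound 1 to compound 3 (0.10 log units; within the scatter); compound 2 stands far apart, since a 110-fold higher number from compound 1 to compound 2 (2.02 log units; beyond the scatter).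

Compound 4 `N#Cc1ccccc1OC1CCN(c2ccc(-n3ccnc3)nn2)CC1` differs from compound 3 by cyano in place of trifluoromethyl on an aromatic carbon. Among the measured compounds shown here, only the step from compound 1 to compound 3 bears on this change, and it was small, so no step beyond the scatter is expected, with a 2.0-fold higher number from compound 3 to compound 4 (0.30 log units; within the scatter). Compound 4 is therefore expected to give about 8 nM, in the range 3 nM to 25 nM.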

Compound 4, half-maximal inhibitory concentration: 236 nM
Compound 4: middle estimate off by 30-fold (1.47 log units), on the low side; the whole stated range lies below it.
By their numbers in this assay, from the lowest: compounds 3 and 1 (each within the scatter of the next); then compound 4; then compound 2.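

At this aromatic carbon, ortho to a large group, the choice of group matters far more than the bromo and trifluoromethyl pair suggested: in this assay there is a 59-fold higher number from compound 3 to compound 4 (1.77 log units; beyond the scatter) and likewise a 47-fold higher number from compound 1 to compound 4 (1.67 log units; beyond the scatter) for cyano in place of bromo. The 2-cyanophenyl group keeps only a modest edge over 4-methylphenyl, with a 2.2-fold lower number from compound 2 to compound 4 (0.35 log units; beyond the scatter) in the same read-out. Nothing available explains why cyano parts so sharply from the other two groups.

Going by these compounds, whether chloro, methyl, methoxy or an amine at this same place would track trifluoromethyl or cyano remains open.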